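The source may report more compounds than this note shows. Statements on the series, on what has been measured and on what is new or still open speak of the compounds shown alone.

Working notes on the series. Compound 1 `CCOC(=O)c1c(-c2ccccc2)c(C#N)c(=O)n(/N=C(\C)c2ccc(NS(=O)(=O)c3ccc(Cl)cc3)cc2)c1N` gives in a functional assay on HepG2 cells (Homo sapiens) for cytotoxicity, read by sulforhodamine B assay, with a stated time of 48 h (a higher number here means a weaker inhibitor, a lower number a stronger inhibitor), a value of 16800 nM. Within the data shown here, compound 2 `CCOC(=O)c1c(-c2ccc(OC)cc2)c(C#N)c(=O)n(/N=C(\C)c2ccc(NS(=O)(=O)c3ccc(Cl)cc3)cc2)c1N` gives in this assay a value of 61700 nM, the highest of the two numbers so far; its nearest neighbour is compound 1, and the only measured step, a 3.7-fold higher number from compound 1 to compound 2 (0.56 log units; beyond the scatter), is modest but beyond the scatter. Compound 3 `CCOC(=O)c1c(-c2ccccc2Cl)c(C#N)c(=O)n(/N=C(\C)c2ccc(NS(=O)(=O)c3ccc(Cl)cc3)cc2)c1N` is not yet measured; it differs from compound 2 by 2-chlorophenyl in place of 4-methoxyphenyl on an aromatic carbon. Among the measured compounds shown here, of the measured steps only a 3.7-fold higher number from compound 1 to compound 2 (0.56 log units; beyond the scatter) bears on this change, and it does so only in part: it covers the loss of the methoxy group, which on its own would be expected to lower the number back toward compound 1, while no measured compound carries a chlorine on this aryl ring, so that part of the change has no precedent here. The expectation for compound 3 is therefore a step of a 2.5-fold lower number from compound 2 to compound 3 (0.39 log units; beyond the scatter) in this assay, with wide uncertainty. The estimate for compound 3 in this assay is 25000 nM, within a range from 8000 nM to 80000 nM.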

Compound 3, half-maximal inhibitory concentration: 11400 nM
Beside the measured number, compound 3's estimate is 2.2-fold (0.34 log units) above it; measured number inside the range.
By their numbers in this assay, from the lowest: compounds 3 and 1 (each within the scatter of the next); then compound 2.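

In this assay, a substituent on this aryl ring does not by itself raise the number: the 2-chlorophenyl group (a 1.5-fold lower number from compound 1 to compound 3 (0.17 log units; within the scatter)) stays level with the unsubstituted phenyl, so compound 2 alone stands apart among the three. The step away from 4-methoxyphenyl (a 5.4-fold lower number from compound 2 to compound 3 (0.73 log units; beyond the scatter)) thus returns the number to the level of compound 1, but it changes both the substituent and its place on the ring, and the two contributions cannot be separated. Nothing available explains the difference between chloro and methoxy at this position. The compounds shown leave open whether 4-chlorophenyl would behave like 2-chlorophenyl, or 2-methoxyphenyl like 4-methoxyphenyl. They also leave open how an amine or a carboxylic acid on this ring would read.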